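Pent-4-enyl chain extension on the aryl ether oxygen

The source may report more compounds than this note shows. Statements on the series, on what has been measured and on what is new or still open speak of the compounds shown alone.

Working notes on three measured compounds and one pending. Compound 2 `COc1ccccc1-c1cnc(OC)n1C` is the smallest member; in a functional assay on LoVo cells (Homo sapiens) for inhibition, read by colorimetric assay and MTT assay, with a stated time of 72 h (on this read-out higher numbers stand for weaker inhibition and lower numbers for stronger inhibition), compound 2 gives 73000 nM, the highest of the three numbers. Compound 3 `C=CCCOc1ncc(-c2ccccc2OC)n1C` gives 24000 nM in this assay, and the step of a 3.0-fold lower number from compound 2 to compound 3 (0.48 log units; beyond the scatter) is modest but beyond the scatter. Compound 1 `C=CCCCCOc1ccccc1-c1cnc(OCCC=C)n1C` gives 12000 nM in this assay; the step of a 2.0-fold lower number from compound 3 to compound 1 (0.30 log units; within the scatter) comes from the change (pent-4-en-1-yl in place of hydrogen on a saturated chain carbon bound to an oxygen on an aromatic ring).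

Compound 4 `C=CCCCCOc1ccccc1-c1cnc(OC)n1C` has not yet been measured. It differs from compound 2 by pent-4-en-1-yl in place of hydrogen on a saturated chain carbon bound to an oxygen on an aromatic ring, the same change that takes compound 3 to compound 1, and the place is the same word for word in both cases. The two starting cores differ by hydrogen in place of allyl on a saturated chain carbon bound to an oxygen on an aromatic ring, so compound 4 carries the longer chain on a core that lacks the allyl group present in compound 3.

Going by the values given here, the step from compound 2 to compound 4 in this assay is estimated at a 2.0-fold lower number from compound 2 to compound 4 (0.31 log units; beyond the scatter) because the only precedent gave a 2.0-fold lower number from compound 3 to compound 1 (0.30 log units; within the scatter), within the scatter, with no evidence that the second core behaves differently. Compound 4 is expected to give about 36000 nM in this assay, plausibly between 15000 nM and 90000 nM.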

Compound 4, half-maximal inhibitory concentration: 47000 nM
Beside the measured number, compound 4's estimate is 1.3-fold (0.12 log units) below it, within the range that was stated.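

In this assay, the pent-4-en-1-yl change gives a 1.6-fold lower number from compound 2 to compound 4 (0.19 log units; within the scatter), and its size agrees with the earlier step on the other core: the same change on two cores in this assay, a 2.0-fold lower number (0.30 log units; within the scatter) from compound 3 to compound 1 and a 1.6-fold lower number (0.19 log units; within the scatter) from compound 2 to compound 4, 1.3-fold (0.11 log units) apart, within the scatter of two such steps

Removing the allyl group gives a 3.9-fold higher number from compound 1 to compound 4 (0.59 log units; beyond the scatter), and the allyl change also agrees across the two cores: the same change on two cores in this assay, a 3.0-fold lower number (0.48 log units; beyond the scatter) from compound 2 to compound 3 and a 3.9-fold lower number (0.59 log units; beyond the scatter) from compound 4 to compound 1, 1.3-fold (0.11 log units) apart, within the scatter of two such steps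

Together these show that, for compound 1, compound 2, compound 3 and compound 4, each change has much the same size on both cores, but only the allyl steps lie beyond the scatter, and they do not establish a rule for the wider series or explain why the numbers move.

Going by these compounds, it remains open whether a longer chain, or an amine or a carboxylic acid in place of pent-4-en-1-yl, would move the number on either core. On these data alone, it is also open whether the agreement between these steps would hold on a third core.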